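The source may report more compounds than this note shows. Statements on the series, on what has been measured and on what is new or still open speak of the compounds shown alone.

Working notes on the series. Two compounds have numbers in an assay on HEK293 cells for antagonist activity at transient receptor potential cation channel subfamily V member 3 (Homo sapiens), read by FLIPR and calcium flux (on this read-out higher numbers stand for weaker inhibition and lower numbers for stronger inhibition), so far. Compound 1 `O[C@H](c1ccccn1)[C@]1(c2cc(C(F)(F)F)ccn2)C[C@H](O)C1` gives 270 nM in this assay. Compound 2 `C[C@]1(c2ccc(OC(F)(F)F)cc2)C[C@](O)(c2ccccn2)CO1` gives 420 nM in this assay. The two values sit within the scatter of each other, so the series shows no separation yet, and compound 1 serves only as the reference point for the next step. Compound 3 `C[C@]1(O)C[C@](c2cc(C(F)(F)F)ccn2)([C@H](O)c2ccccn2)C1` is the one to be measured next. Relative to compound 1 it carries methyl in place of hydrogen on a saturated ring carbon, a methyl in place of hydrogen on a saturated ring carbon of the shared core. Going by the values given here, no pair of measured compounds differs by a single change, so nothing in the data so far shows what such a step does. With that in mind the step of a 1.1-fold higher number from compound 1 to compound 3 (0.05 log units; within the scatter) is expected to stay within the scatter, in no particular direction. Compound 3 is therefore estimated at 300 nM in this assay, with a range from 120 nM to 800 nM.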

Compound 3, antagonist equilibrium constant: 560 nM
For compound 3 the middle estimate is 1.9-fold (0.27 log units) below the measured one; the measured number falls inside the stated range.
By their numbers in this assay, from the lowest: compounds 1, 2 and 3 (each within the scatter of the next, the first and the last beyond it).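

In this assay the series now has its first single-change step, a 2.1-fold higher number from compound 1 to compound 3 (0.32 log units; beyond the scatter) and so a methyl in place of hydrogen on a saturated ring carbon of the four-membered non-aromatic ring of carbon only is not silent, although the step is modest. Going by these compounds alone, its direction is towards weaker inhibition, something the earlier compounds could not show, since neither of them differed from the other in one place only. No evidence at hand bears on why the step goes this way.

From the compounds shown here alone, whether an ethyl group or an amine on this same ring carbon would move the number further in that direction stays open. One step also leaves open whether a fluorine there would behave like the methyl.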